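The compounds below may be only part of what the source reports. "The series", "measured", "known", "first", "only" and "open" are said of these compounds alone.

Working notes on the series. In an assay for inhibition of cathepsin S (Homo sapiens) (on this read-out lower numbers stand for stronger inhibition and higher numbers for weaker inhibition), compound 1 `CC(C)C[C@H](NC(=O)N1CCOCC1)C(=O)NCC#N` gives 124 nM, the lowest of the two numbers recorded so far; compound 2 `CC(C)CC[C@H](NC(=O)N1CCOCC1)C(=O)N[C@@H](C#N)CCc1ccccc1`, which differs from it in several places, gives 387 nM. Compound 3 `CC(C)C[C@H](NC(=O)N1CCOCC1)C(=O)N[C@H](C#N)COCc1ccc(Cl)cc1`, not yet measured, differs from compound 1 by ((4-chlorobenzyl)oxy)methyl in place of hydrogen on a saturated chain carbon bound to an amide-type nitrogen and a triple-bonded carbon. Among the compounds with values here, no single-change step among the measured compounds bears on this substitution, so the size of the step is uncertain; the expectation is a modest move toward stronger inhibition, of a 1.8-fold lower number from compound 1 to compound 3 (0.25 log units; within the scatter), with no firm confidence that it falls beyond the scatter. For compound 3 in this assay the estimate is 70 nM, within a range from 15 nM to 350 nM.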

Compound 3, half-maximal inhibitory concentration: 27 nM
Compound 3: the middle estimate sits 2.6-fold (0.41 log units) above what was measured, within the range that was stated.
By their numbers in this assay, from the lowest: compound 3; then compound 1; then compound 2.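

In this assay, within the data shown here, ((4-chlorobenzyl)oxy)methyl in place of hydrogen on a saturated chain carbon bound to an amide-type nitrogen and a triple-bonded carbon gives a 4.6-fold lower number from compound 1 to compound 3 (0.66 log units; beyond the scatter) as the first single-change step. The position therefore accepts this substituent with stronger inhibition, and the step lies beyond the scatter. Nothing on hand accounts for the gain. Still open, on these data alone, is which part of the substituent carries the step: a methyl group, a hydroxymethyl group or benzyloxymethyl lacking the chlorine could separate these parts.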